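This account rests on a few compounds, and the source may have more. Where it says the series, first, only, none or still open, it means among the compounds named here.

compound 1 `CCC(=O)c1cc(-c2ccc(Cl)cc2)n(-c2ccc(S(=O)(=O)N(C)C)cc2)c1C` gives 1200 nM
compound 2 `CCOC(=O)c1cc(-c2ccc(Cl)cc2)n(-c2ccc(S(N)(=O)=O)cc2)c1C` gives 4200 nM
compound 3 `CCC(=O)c1cc(-c2ccc(F)cc2)n(-c2ccc(S(N)(=O)=O)cc2)c1C` gives 29300 nM

These three numbers come from a physicochemical assay for solubility, read by HPLC, in phosphate buffer, measured as kinetic solubility, at pH 7.4 (on this read-out lower numbers stand for lower solubility and higher numbers for higher solubility), and compound 3 stands highest among them. Compound 2 is its nearest neighbour and compound 1 the furthest, and both gaps lie beyond the scatter.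

Compound 4 `CCC(=O)c1cc(-c2cccc(Cl)c2)n(-c2ccc(S(N)(=O)=O)cc2)c1C` has not yet been measured. It carries 3-chlorophenyl in place of the 4-fluorophenyl of compound 3, on an aromatic carbon next to the ring nitrogen, and the rest of the structure stays the same (3-chlorophenyl in place of 4-fluorophenyl on an aromatic carbon).

Going by the values given here, no two measured compounds differ in one place only, so no direct step is available as a guide. Among the compounds with values here, the values show only that compound 3, the one with a fluorophenyl group, gives 29300 nM, while compound 2 (4200 nM) and compound 1 (1200 nM), the two with a chlorophenyl group, both sit lower. Three compounds make thin ground, but on it the expected move in this assay is downward and beyond the scatter (estimated step: a 4.9-fold lower number from compound 3 to compound 4 (0.69 log units; beyond the scatter)). The estimate for compound 4 is 6000 nM with an expected range from 2000 nM to 18000 nM.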

Compound 4, solubility: 12600 nM
Compound 4: middle estimate off by 2.1-fold (0.32 log units), on the low side; low and high end bracket the measured number.
By their numbers in this assay, from the lowest: compound 1; then compound 2; then compound 4; then compound 3.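

Going by these compounds alone, for the first time, two measured compounds differ in one place only. In this assay, 3-chlorophenyl in place of 4-fluorophenyl, on an aromatic carbon next to the ring nitrogen, gives a 2.3-fold lower number from compound 3 to compound 4 (0.37 log units; beyond the scatter), a modest step but one that shows the read-out responds to a change at this position while the rest of the structure stays fixed. Both the halogen and its place on the phenyl ring differ in this single swap, although the two groups match in heavy-atom count and in having no hydrogen-bond donors or acceptors, and no measurement here explains the step.

The compounds shown leave open how much of the step belongs to the change from fluorine to chlorine and how much to the halogen's place on the ring, a question that 4-chlorophenyl or 3-fluorophenyl on this same structure could separate. On these data alone, it also remains open how this position would respond to a group other than a halogen-bearing phenyl, such as a plain phenyl, a methoxyphenyl or an aminophenyl.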